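Nitro in Place of Hydrogen on the Aryl Ketone

The source may hold more compounds than are shown below. What is called first, only, known or untested is meant among the compounds shown, and "the series" means these compounds.

For the measured compounds named here, compound 1, `COc1ccc(-c2cc3ccccc3nc2/C=C/C(=O)c2ccccc2)cc1`, is one of three compounds measured in a functional assay on NCI-H460 cells (Homo sapiens) for antiproliferative activity, read by XTT assay, with a stated time of 72 h (on this read-out lower numbers stand for stronger inhibition and higher numbers for weaker inhibition), where compound 1 gives 6670 nM. Its two companions share the same core. Compound 2, `COc1ccc(-c2cc3ccccc3nc2/C=C/C(=O)c2ccc(O)cc2)cc1`, gives 6930 nM, and compound 3, `COc1ccc(-c2cc3ccccc3nc2/C=C/C(=O)c2c(OC)cccc2OC)cc1`, gives 6630 nM. On these numbers compound 1 stands second highest of the three, with compound 3 nearest and compound 2 furthest, both steps within the scatter. The two changes made on the aryl ketone ring are a 1.0-fold higher number from compound 1 to compound 2 (0.02 log units; within the scatter) and a 1.0-fold lower number from compound 1 to compound 3 (0.00 log units; within the scatter), so neither a hydroxy nor a pair of methoxy groups on that ring moves the number beyond the scatter.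

Compound 4, `COc1ccc(-c2cc3ccccc3nc2/C=C/C(=O)c2ccc([N+](=O)[O-])cc2)cc1`, is not yet measured. It differs from compound 1 by nitro in place of hydrogen on an aromatic carbon. Both steps that bear on it, from compound 1 to compound 2 and from compound 1 to compound 3, are flat, so no step beyond the scatter is expected in this assay. The estimate for compound 4 is 6700 nM, within 3300 nM to 13500 nM, which would mean an expected step of a 1.0-fold higher number from compound 1 to compound 4 (0.00 log units; within the scatter).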

Compound 4, half-maximal inhibitory concentration: 6470 nM
Compound 4: the middle estimate sits 1.0-fold (0.02 log units) above what was measured, within the range that was stated.
By their numbers in this assay, from the lowest: compounds 4, 3, 1 and 2 (each within the scatter of the next).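

In this assay, nitro in place of hydrogen on the aryl ketone ring gives a 1.0-fold lower number from compound 1 to compound 4 (0.01 log units; within the scatter) and so joins hydroxy and the pair of methoxy groups in leaving the number within the scatter. The exchange for the other substituted rings is just as flat, with 4-nitrophenyl in place of 2,6-dimethoxyphenyl giving a 1.0-fold lower number from compound 3 to compound 4 (0.01 log units; within the scatter) and nitro in place of hydroxy giving a 1.1-fold lower number from compound 2 to compound 4 (0.03 log units; within the scatter) within this set of four. No measurement is at hand that would explain this flatness.

On these data alone, whether it would hold for an amine or a carboxylic acid at this place on the ring remains open. The compounds shown also leave open whether any change elsewhere on the shared core would move the number beyond the scatter.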